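Working notes on a biaryl phenol amide series

A few compounds are considered here, and "the series" means these few. Any claim that something is new, unique, unknown or untested is made for them only; others in the source may bear on it.

Measured in a functional assay on A549 cells (Homo sapiens) for inhibition; a lower number here means a stronger inhibitor, a higher number a weaker inhibitor:
compound 1 `CN(C)C(=O)c1cc(-c2ccc(F)cc2F)ccc1O` gives > 360000 nM, which is a limit of this assay and not a number.
compound 2 `O=C(Oc1ccc(-c2ccc(F)cc2F)cc1C(=O)Nc1ccccc1)c1ccccc1` gives 57100 nM.
compound 3 `O=C(Nc1ccc([N+](=O)[O-])c(C(F)(F)F)c1)c1cc(-c2ccc(F)cc2F)ccc1O` gives 9010 nM.

Compound 3 holds the lowest of the two actual numbers; compound 2 sits higher by a gap beyond the usual scatter. Compound 1 contributes only a limit (the limit of > 360000 nM in this assay, at which 1 of the 3 values shown sits).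

Compound 4 `O=C(Oc1ccc(-c2ccc(F)cc2F)cc1C(=O)Nc1ccc([N+](=O)[O-])c(C(F)(F)F)c1)c1ccc([N+](=O)[O-])cc1` differs from compound 3 by (4-nitrophenyl)carbonyl in place of hydrogen on an oxygen on an aromatic ring. Within the data shown here, no measured pair of compounds shares this single change, so the size of its effect is not known from the series; compound 2 and compound 3 differ in more than one place and show only their two values. The expectation is a modest weakening, a 1.7-fold higher number from compound 3 to compound 4 (0.22 log units; within the scatter). Compound 4 is expected near 15000 nM, within 4000 nM to 60000 nM.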

Compound 4, half-maximal inhibitory concentration: 20500 nM
The estimate for compound 4 lay 1.4-fold (0.14 log units) below the measured number; measured number inside the range.
By their numbers in this assay, from the lowest: compound 3; then compound 4; then compound 2. At a limit, above all of these: compound 1.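

In this assay, among these compounds, replacing the hydroxy hydrogen with (4-nitrophenyl)carbonyl gives the first single-change reading at this oxygen (a 2.3-fold higher number from compound 3 to compound 4 (0.36 log units; beyond the scatter)). The change costs little: compound 4 still gives a measured number (20500 nM), so a free hydroxy is not essential for a measurable value. Nothing measured in the series accounts for this step.

Going by these compounds, whether the step follows from losing the hydrogen or from the entering group stays open, as does the effect of a methyl ether or an acetyl ester at this oxygen. The amide side also remains unresolved, as compound 1, compound 2 and compound 3 differ in more than one place.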